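Chloro to Methyl on Compound 2

A few compounds are considered here, and "the series" means these few. Any claim that something is new, unique, unknown or untested is made for them only; others in the source may bear on it.

Of the compounds shown here, two have so far been tested in an ADME assay on BHK-21 cells (Mesocricetus auratus) for cytotoxicity, read by MTT assay, with a stated time of 72 h; on this read-out lower numbers stand for higher toxicity in this test and higher numbers for lower toxicity in this test: compound 1 `Cc1ccc(-c2nn(-c3ccccc3)cc2CNc2ccc(Br)cc2)cc1` and compound 2 `Clc1ccc(NCc2cn(-c3ccccc3)nc2-c2ccc(Cl)cc2)cc1`. Compound 1 reads > 100000 nM, which is a limit of the assay and not a number. For the measured compounds named here, compound 2 gives 73000 nM, the only actual number available, so it stands alone as the reference point. The next compound to be measured is compound 3 `Cc1ccc(-c2nn(-c3ccccc3)cc2CNc2ccc(Cl)cc2)cc1`. Compared with compound 2, it has methyl in place of chloro on an aromatic carbon, para to a large group, turning 4-chlorophenyl into 4-methylphenyl (methyl in place of chloro on an aromatic carbon). Going by the values given here, no measured step is available as a guide. In this assay the expected step is a 1.2-fold higher number from compound 2 to compound 3 (0.09 log units; within the scatter), small, slightly upward and within the usual scatter. Compound 3 is estimated at 90000 nM, with an expected range from 40000 nM to 160000 nM.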

Compound 3, half-maximal cytotoxic concentration: > 100000 nM
Compound 3 gave a limit, no number (the forecaster's own chance of this, stated with the estimate: 45%); at least 1.1-fold (0.04 log units) between middle value and limit.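

In this assay, placing methyl in place of chloro on this aromatic carbon, which turns 4-chlorophenyl into 4-methylphenyl, gives an at least 1.3-fold higher number from compound 2 to compound 3 (0.13 log units; that floor lies within the scatter), the first direction seen for a change at this position, though only as a floor. The step between compound 1 and compound 3 cannot be read, as both values are limits of the assay and not numbers. Most of what is shown now rests on that one limit: the limit of > 100000 nM in this assay, at which 2 of the 3 values shown sit.

For the compounds shown here, how far compound 3 actually lies from compound 2 stays open, and compound 2 remains the only compound with a number. Also open, going by these compounds, is what an amine, a methoxy group or a carboxylic acid on this aromatic carbon would read in this assay.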